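The source may report more compounds than this note shows. Statements on the series, on what has been measured and on what is new or still open speak of the compounds shown alone.

Compound 1, `Cc1ccc(C)c(NC(=O)CSc2nnc(-c3ccoc3C)n2Cc2ccco2)c1`, gives in a functional assay on CHO cells for antagonist activity at Orexin/Hypocretin receptor type 1 (Homo sapiens), read by FLIPR and calcium flux (on this read-out higher numbers stand for weaker inhibition and lower numbers for stronger inhibition), only a limit, > 15800 nM.
Compound 2, `Cc1occc1-c1nnc(SCC(=O)Nc2ccc(F)c(Cl)c2)n1Cc1ccco1`, gives in this assay 1000 nM.

Compound 2 therefore holds the only actual number shown in this assay; the other value, (the limit of > 15800 nM in this assay, at which 1 of the 2 values shown sits), is a limit and not a number. For the measured compounds named here, the single measured step, an at least 15-fold lower number from compound 1 to compound 2 (1.19 log units; beyond the scatter), is the one that bears on the change now considered, and it was large.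

Compound 3, `Cc1ccc(NC(=O)CSc2nnc(-c3ccoc3C)n2Cc2ccco2)cc1`, differs from compound 2 in 4-methylphenyl in place of 3-chloro-4-fluorophenyl on an amide-type nitrogen. The group that enters, 4-methylphenyl, carries a methyl substituent as the 2,5-dimethylphenyl of compound 1 does, while the halogens of compound 2 are gone. Reading the measured step backwards, the number for compound 3 is expected to rise, likely by a large step, an 8.0-fold higher number from compound 2 to compound 3 (0.90 log units; beyond the scatter). For compound 3 the estimate in this assay is 8000 nM, expected within 2000 nM to 30000 nM, with a real chance that only a limit is reported.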

Compound 3, inhibition constant: > 15800 nM
Compound 3 ended at the assay's limit; the forecaster's own chance of this, stated with the estimate: 40%; at least 1.9-fold (0.29 log units) between middle value and limit.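

Replacing 3-chloro-4-fluorophenyl with 4-methylphenyl on the amide-type nitrogen gave an at least 15-fold higher number from compound 2 to compound 3 (1.19 log units; beyond the scatter) in this assay, so the number held by compound 2 does not survive when the halogens leave. Moving from the 2,5-dimethylphenyl of compound 1 to a single methyl group did not bring a number back either: compound 3 gives > 15800 nM, which is a limit of the assay and not a number. The step between compound 1 and compound 3 cannot be read, as both values are limits: the limit of > 15800 nM in this assay, at which 2 of the 3 values shown sit.

Of the three groups shown on this nitrogen, only 3-chloro-4-fluorophenyl yields a number, and the compounds leave open whether the chlorine, the fluorine or the pair accounts for it. Plain phenyl, 3-chlorophenyl and 4-fluorophenyl at this place would be needed to separate these possibilities.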